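This account rests on a few compounds, and the source may have more. Where it says the series, first, only, none or still open, it means among the compounds named here.

Working notes on the series.

Compound 1 `CS(=O)(=O)c1ccc(Nc2nccc(Nc3nc4ccc(Cl)cc4s3)n2)cc1` is the reference point. In a functional assay on HCT-116 cells (Homo sapiens) for antiproliferative activity, read by MTT assay, with a stated time of 48 h (a higher number here means a weaker inhibitor, a lower number a stronger inhibitor), compound 1 gives 1350 nM. Among the measured compounds shown here, the only other measured member, compound 2 `COc1ccc2nc(Nc3ccnc(Nc4ccc(S(C)(=O)=O)cc4)n3)sc2c1`, carries a methoxy in place of chloro on an aromatic carbon, and in this assay compound 2 gives 2270 nM. For the measured compounds named here, that step, a 1.7-fold higher number from compound 1 to compound 2 (0.23 log units; within the scatter), does not separate the two: compound 1 and compound 2 sit within the scatter of each other, so on the numbers so far compound 1 stands apart from nothing.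

Compound 3 `CS(=O)(=O)c1ccc(Nc2ncc(F)c(Nc3nc4ccc(Cl)cc4s3)n2)cc1` is not yet measured. It differs from compound 1 by fluoro in place of hydrogen on an aromatic carbon. Going by the values given here, no measured step concerns this change; the single step available, from a chloro to a methoxy elsewhere on the shared core, was within the scatter and is not of the same kind, so it gives no direct guidance. With nothing in the data pointing to a large move in either direction, the expected step in this assay is small and within the scatter.

Compound 3 is therefore expected to give about 1200 nM in this assay, in a range from 500 nM to 3000 nM. The expected step is a 1.1-fold lower number from compound 1 to compound 3 (0.05 log units; within the scatter).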

Compound 3, half-maximal inhibitory concentration: 20700 nM
The estimate for compound 3 lay 17-fold (1.24 log units) below the measured number, outside the stated range (above it).
By their numbers in this assay, from the lowest: compounds 1 and 2 (each within the scatter of the next); then compound 3.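

In this assay, the position on the six-membered aromatic ring with 2 nitrogen proves far from silent: the step of a 15-fold higher number from compound 1 to compound 3 (1.19 log units; beyond the scatter) comes from fluoro in place of hydrogen, a change of only 1 heavy atom. Among the compounds shown here, the earlier step of a 1.7-fold higher number from compound 1 to compound 2 (0.23 log units; within the scatter) showed only that methoxy in place of chloro at another place on the shared core leaves the number within the scatter, so this aromatic carbon, ortho to a large group and para to a large group, is the first place where a change clearly weakens the compound. Nothing available explains this loss of activity.

The compounds shown leave open whether the loss belongs to fluoro itself or to any group other than hydrogen on this carbon, a question that a methyl, a chloro or an amine at the same place would help to settle. They also leave open whether fluoro at this carbon has an effect of the same size on the methoxy compound, compound 2, as on the chloro compound, compound 1.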